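The source may report more compounds than this note shows. Statements on the series, on what has been measured and on what is new or still open speak of the compounds shown alone.

Measured in a functional assay on H4 cells for agonist activity at growth hormone secretagogue receptor type 1 (Homo sapiens), read by FLIPR; on this read-out higher numbers stand for an effect only at larger amounts of compound and lower numbers for an effect already at smaller amounts:

Compound 1, `CN(c1ccccc1CCCn1nnnc1[C@@H](COCc1ccccc1)NC(=O)C(C)(C)N)S(C)(=O)=O`: 14 nM
Compound 2, `CC(C)(N)C(=O)N[C@H](COCc1ccccc1)c1nnn(Cc2ccccc2)n1`: 1120 nM
Compound 3, `CC(C)(N)C(=O)N[C@H](COCc1ccccc1)c1nnn(CC2Cc3ccccc3N2S(C)(=O)=O)n1`: 546 nM

Among these three, compound 2 has the highest number, meaning it needs the largest amount of compound to produce its effect. Compound 3 stands nearest to it, and compound 1 furthest; both gaps lie beyond the usual scatter of this assay, so compound 2 is the weakest of the three.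

Compound 4, `CC(C)(N)C(=O)N[C@H](COCc1ccccc1)c1nnn(C/C=C/c2ccccc2)n1`, is not yet measured. It keeps the shared core and the amide side chain of compound 2 and differs in one place: 2-phenylethenyl in place of phenyl on a saturated chain carbon bound to an aromatic nitrogen. No measured pair isolates exactly this change, so the expectation cannot be anchored to a shown step and rests only on the spread of the three known values. A modest move toward a lower number, around the edge of the scatter, is expected for compound 4, as the step of a 2.0-fold lower number from compound 2 to compound 4 (0.31 log units; beyond the scatter). In this assay compound 4 is therefore estimated at 550 nM, with a plausible range from 150 nM to 2000 nM.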

Compound 4, half-maximal effective concentration: 517 nM
Compound 4: middle estimate off by 1.1-fold (0.03 log units), on the high side; the range from low to high includes it.
By their numbers in this assay, from the lowest: compound 1; then compounds 4 and 3 (each within the scatter of the next); then compound 2.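

In this assay the place on a saturated chain carbon bound to an aromatic nitrogen now has its first reading for a single change: putting 2-phenylethenyl in place of phenyl gives a 2.2-fold lower number from compound 2 to compound 4 (0.34 log units; beyond the scatter) and so shows that this place responds to the group it carries. The step is modest, yet it lies beyond the scatter, and the larger group, with its one double bond outside aromatic rings, keeps the compound active. Nothing available explains why the number falls.

Going by these compounds, whether the change comes from the double bond or from the longer chain stays open, and a saturated 3-phenylpropyl group at the same place would separate the two. Also open, on these data alone, is how an amine or a carboxylic acid on the phenyl ring would read here.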